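Cytotoxicity of Pentafluorophenylsulfonyl Azetidine Amides on Breast Epithelial Cells

The source may report more compounds than this note shows. Statements on the series, on what has been measured and on what is new or still open speak of the compounds shown alone.

Two compounds of this series have been examined in an ADME assay on MCF-10A cells (Homo sapiens) for cytotoxicity, with a stated time of 72 h; on this read-out higher numbers stand for an effect only at larger amounts of compound and lower numbers for an effect already at smaller amounts. Compound 1 `O=C(NO)c1ccc(N(Cc2ccc(C3CCCCC3)cc2)C(=O)[C@H]2CCN2S(=O)(=O)c2c(F)c(F)c(F)c(F)c2F)cc1` gives 7900 nM. Compound 2 `NC(=O)c1ccc(N(Cc2ccc(C3CCCCC3)cn2)C(=O)[C@H]2CCN2S(=O)(=O)c2c(F)c(F)c(F)c(F)c2F)cc1O`, which carries a 4-carbamoyl-3-hydroxyphenyl on the amide-type nitrogen, gives 7200 nM. Compound 2 has the lower of the two numbers, yet its nearest neighbour is compound 1 and the gap between them is within the scatter, so the two values show the same picture and no order between them can be drawn.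

Compound 3 `O=C([C@H]1CCN1S(=O)(=O)c1c(F)c(F)c(F)c(F)c1F)N(Cc1ccc(C2CCCCC2)cn1)c1cc2[nH]ncc2cc1F` has not yet been measured in this assay . It differs from compound 2 in one place: 5-fluoro-1H-indazol-6-yl in place of 4-carbamoyl-3-hydroxyphenyl on an amide-type nitrogen. For the measured compounds named here, no measured pair in this set shows the effect of such a change, so its size is unknown from the data; the two measured compounds, which differ in several places at once, sit close together in this assay , which argues for a modest step here as well. The step from compound 2 to compound 3 is expected to be a 1.4-fold lower number from compound 2 to compound 3 (0.16 log units; within the scatter), in the direction of a slightly lower number, though a step no larger than the scatter is also plausible. Compound 3 is estimated at 5000 nM, with a range from 1500 nM to 15000 nM.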

Compound 3, half-maximal effective concentration: 4900 nM
Compound 3: middle estimate off by 1.0-fold (0.01 log units), on the high side; the range from low to high includes it.
By their numbers in this assay, from the lowest: compounds 3, 2 and 1 (each within the scatter of the next).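

With compound 3, the series gains its first pair that differs in one place, and in this assay the change on the amide-type nitrogen gives a 1.5-fold lower number from compound 2 to compound 3 (0.17 log units; within the scatter). This pair shows directly that 5-fluoro-1H-indazol-6-yl, with its five-membered aromatic ring carrying 2 hetero atoms, its fluorine, 1 hydrogen-bond donor and 1 hydrogen-bond acceptor, can stand in place of 4-carbamoyl-3-hydroxyphenyl, with 2 hydrogen-bond donors and 2 hydrogen-bond acceptors, without the read-out moving beyond the scatter, so at this position these differences in ring make-up and counts leave no clear mark on this cytotoxicity read-out. Nothing at hand explains why the two groups give such similar numbers.

On these data alone, it remains open whether this insensitivity holds only for these two aromatic groups or extends to quite different ones on the same nitrogen, such as a phenyl bearing a carboxylic acid or an amine. Also open, as far as these compounds go, is what the fluorine contributes within the new group, a question that the unsubstituted 1H-indazol-6-yl would address directly.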